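The source may hold more compounds than are shown below. What is called first, only, known or untested is meant among the compounds shown, and "the series" means these compounds.

Measured in a functional assay on HepG2 cells (Homo sapiens) for cytotoxicity, with a stated time of 72 h; on this read-out lower numbers stand for an effect already at smaller amounts and higher numbers for an effect only at larger amounts of compound:
- Compound 1 `C=C[C@@](C)(/C=C/c1ccc(O)c(/C=C/C#N)c1)CCC=C(C)C`: > 52000 nM, a limit
- Compound 2 `C=C[C@@](C)(/C=C/c1ccc(O)c(/C=C/C(=O)OCC)c1)CCC=C(C)C`: > 52000 nM, a limit
- Compound 3 `C=C[C@@](C)(/C=C/c1ccc(O)c(/C=C/c2ccc(F)cc2)c1)CCC=C(C)C`: > 52000 nM, a limit

Compound 3 has no number, only the limit > 52000 nM. The whole series stands at the limit of > 52000 nM in this assay, at which 3 of the 3 values shown sit.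

Compound 4 `C=C[C@@](C)(/C=C/c1ccc(O)c(/C=C/c2ccc(Cl)cc2)c1)CCC=C(C)C` carries chloro in place of fluoro on an aromatic carbon, para to a large group (chloro in place of fluoro on an aromatic carbon).

Three measured steps swap the group on the double-bonded chain carbon: a step that the two limits leave unreadable from compound 1 to compound 2, a step that the two limits leave unreadable from compound 1 to compound 3 and a step that the two limits leave unreadable from compound 2 to compound 3. None of them exchanges fluoro for chloro, and their sizes cannot be read. The expectation is therefore a step that the limit leaves unreadable from compound 3 to compound 4, with no direction that these limits can show.

Compound 4 is estimated at 60000 nM, with an expected range of 25000 nM to 120000 nM, and it may well be reported only as a limit.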

Compound 4, half-maximal effective concentration: > 52000 nM
Compound 4 was reported as a limit; the forecaster's own chance of this, stated with the estimate: 80%; the middle value does not contradict the limit.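

Within the data shown here, compound 4, like compound 1, compound 2 and compound 3, is reported only as a limit, so no step to compound 4 can be read: the limit of > 52000 nM in this assay, at which 4 of the 4 values shown sit. The compounds shown leave open what size of effect, if any, chloro in place of fluoro has.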